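The compounds below may be only part of what the source reports. "The series", "measured", "known", "first", "only" and "open" are said of these compounds alone.

Compound 2 `Cc1csc2cc([C@H](C)Nc3ncnc(N)c3C#N)c(-c3cccc(CN(C)CCCN(C)Cc4ccc(Cl)cc4)c3)c(=O)n12` gives 8.8 in a physicochemical assay for acid dissociation. Among the three compounds measured in this assay it carries the lowest number, but only by a small margin: compound 3 `Cc1csc2cc([C@H](C)Nc3ncnc(N)c3C#N)c(-c3cccc(CN4CCC(CN(C)Cc5ccccn5)CC4)c3)c(=O)n12` gives 9, and compound 1 `Cc1csc2cc([C@H](C)Nc3ncnc(N)c3C#N)c(-c3cccc(CN(C)CCCCN(C)Cc4ccccc4)c3)c(=O)n12` gives 9.1; both sit within the usual scatter of the number for compound 2, so these three compounds cannot be told apart on the numbers shown.

Compound 4 `Cc1csc2cc([C@H](C)Nc3ncnc(N)c3C#N)c(-c3cccc(CN(C)CCCN4C[C@@H](C)O[C@@H](C)C4)c3)c(=O)n12` is derived from compound 2 by a single change: 2,6-dimethylmorpholin-4-yl in place of (4-chlorobenzyl)(methyl)amino on a saturated chain carbon, three bonds along the chain from an amine nitrogen. For the measured compounds named here, only one measured step touches the same place. It is a number 0.30 log units lower from compound 1 to compound 2 (within the scatter), and it stayed within the scatter. Compound 3 differs from compound 2 in more than one place, so its number offers a comparison only, and it, too, lies within the scatter of the number for compound 2. Going by the values given here, no measured step involves the group that enters here, so the expectation rests on the one change already made at this place, which left this assay unchanged within the scatter.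

The expected step is therefore a number 0.10 log units higher from compound 2 to compound 4 (within the scatter), none beyond the scatter. Compound 4 is estimated at 8.9 in this assay, with a range from 8.3 to 9.5.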

Compound 4, acid dissociation constant: 8.5
Compound 4: the middle estimate sits 0.40 log units above what was measured; low and high end bracket the measured number.
By their numbers in this assay, from the lowest: compounds 4, 2, 3 and 1 (each within the scatter of the next, the first and the last beyond it).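

In this assay, the step at this place now covers a much larger swap of groups: 2,6-dimethylmorpholin-4-yl, a non-aromatic ring holding two hetero atoms, replaces (4-chlorobenzyl)(methyl)amino, which carries a carbon-only aromatic ring and a chlorine, and the result is a number 0.30 log units lower from compound 2 to compound 4 (within the scatter). So even this change of ring type and atoms leaves the read-out indistinguishable from its starting point, while the step of a number 0.60 log units lower from compound 1 to compound 4 (beyond the scatter), in which 2,6-dimethylmorpholin-4-yl replaces (benzyl(methyl)amino)methyl, is the first in this set to go beyond the scatter, though only modestly. Nothing available here explains either step, so the numbers record what happened at this place and not why.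

As far as these compounds go, it remains open whether the plain morpholin-4-yl ring, without its two methyl groups, would give a number close to that of the 2,6-dimethylmorpholin-4-yl compound, and whether a piperidine or a piperazine ring in the same place would do the same. Also open, from the compounds shown here alone, is how 2,6-dimethylmorpholin-4-yl would read out on a longer chain, which would separate the effect of the ring from that of the chain length.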